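This account rests on a few compounds, and the source may have more. Where it says the series, first, only, none or still open, it means among the compounds named here.

Measured compounds:
compound 1 `CCC(=O)Nc1cccc(Oc2nc(Nc3ccc(N4CCN(C)CC4)cc3)ncc2Cl)c1` — 82.6%
compound 2 `CCC(=O)Nc1cccc(Oc2nc(Nc3ccc(N4CCCC4)cc3OC)ncc2Cl)c1` — "not active" (no number reported)
compound 3 `CCC(=O)Nc1cccc(Oc2ccnc(Nc3ccc(N4CCN(C)CC4)cc3)n2)c1` — 48.8%

In an assay on isolated protein for inhibition of NUAK family SNF1-like kinase 2 (Homo sapiens), read by ADP-Glo, with a stated time of 60 min, tested at 10 uM, in the presence of a further agent that is not named here (a lower number here means less inhibition, a higher number more inhibition at the concentration tested (going by the name of the read-out)), compound 1 gives 82.6%, the highest of the two numbers reported. Compound 3 gives 48.8%. Compound 2 is reported as not active, with no number attached. Within the data shown here, the single step measured in one place is a number 33.8 percentage points lower from compound 1 to compound 3 (beyond the scatter), hydrogen in place of chloro on an aromatic carbon of the shared core.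

Compound 4 `CCC(=O)Nc1cccc(Oc2nc(Nc3ccc(N(CC)CC)cc3)ncc2Cl)c1` is not yet measured. It differs from compound 1 as follows: diethylamino in place of 4-methylpiperazin-1-yl on an aromatic carbon. Among the measured compounds shown here, no measured step touches this part of the molecule, so nothing among the three compounds bears directly on the change. Compound 2 carries a different amine together with a methoxy group, two changes at once, and for compound 2 there is only the verdict as reported, reported as not active, with no number. On that footing the estimate for compound 4 is a modest decrease, a number 14.6 percentage points lower from compound 1 to compound 4 (beyond the scatter), with wide uncertainty. Compound 4 is therefore expected to give about 68%, ranging from 40% to 88%.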

Compound 4, a percentage reported as inhibition, at one concentration (the size of the read-out at that concentration, not a potency): 21.2%
Compound 4: the middle estimate sits 46.8 percentage points above what was measured, and the stated range ends above it.
By their numbers in this assay, from the lowest: compound 4; then compound 3; then compound 1.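

In this assay, the step from 4-methylpiperazin-1-yl to diethylamino on the aromatic carbon para to a large group is a number 61.4 percentage points lower from compound 1 to compound 4 (beyond the scatter), which shows that inhibition at this concentration depends strongly on the group at this place. Among these compounds, the earlier compounds could not show this, since the only single-place step among them concerned the chloro group on the shared core. The entering group has no ring and one nitrogen fewer, but the step cannot separate these two differences, and no measurement at hand accounts for the loss.

The compounds shown leave open whether the ring alone is enough, as a piperidin-1-yl group would test, or whether the second ring hetero atom counts as well, as a morpholin-4-yl group would test. They also leave open whether the methyl on the piperazine matters, which the unsubstituted piperazin-1-yl group would address.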